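The source may report more compounds than this note shows. Statements on the series, on what has been measured and on what is new or still open speak of the compounds shown alone.

Series in a functional assay on the whole organism with Rattus norvegicus as the target; on this read-out lower numbers stand for an effect already at smaller amounts and higher numbers for an effect only at larger amounts of compound:
- Compound 1 `CCOCCOC(=O)C(=O)Nc1nc(-c2cc(Cl)no2)cs1`: 6 mg/kg
- Compound 2 `CCOCCOC(=O)C(=O)Nc1nc(-c2conc2C)cs1`: > 100 mg/kg

Compound 2 stands at a limit, not a number: the limit of > 100 mg/kg in this assay, at which 1 of the 2 values shown sits.

Compound 3 `CCOCCOC(=O)C(=O)Nc1nc(-c2cc(C)on2)cs1` differs from compound 2 by 5-methyl-1,2-oxazol-3-yl in place of 3-methyl-1,2-oxazol-4-yl on an aromatic carbon: the two have the same atoms, joined differently. Among the compounds with values here, the one measured step, an at least 16-fold higher number from compound 1 to compound 2 (1.22 log units; beyond the scatter), exchanges the group at this same place and is large, so the read-out in this assay is clearly sensitive to this group. A step towards a lower number is therefore expected, although another limit remains possible. The expected step is an at least 3.3-fold lower number from compound 2 to compound 3 (0.52 log units; beyond the scatter). For compound 3 the estimate is 30 mg/kg, with an expected range of 6 mg/kg to 100 mg/kg.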

Compound 3, dose for half-maximal effect: 1.3 mg/kg
The estimate for compound 3 lay 23-fold (1.36 log units) above the measured number; the whole stated range lies above it.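

In this assay, the read-out separates two groups with the same atoms, joined differently: 5-methyl-1,2-oxazol-3-yl in place of 3-methyl-1,2-oxazol-4-yl gives an at least 76-fold lower number from compound 2 to compound 3 (1.88 log units; beyond the scatter) on the same aromatic carbon. The chlorine of the 3-chloro-1,2-oxazol-5-yl group is thus not required for an effect at small amounts, as 5-methyl-1,2-oxazol-3-yl in its place gives a 4.6-fold lower number from compound 1 to compound 3 (0.66 log units; beyond the scatter) in this series. Compound 2 gives only a limit, so the first step has no fixed size: the limit of > 100 mg/kg in this assay, at which 1 of the 3 values shown sits.

Open, on these data alone, is whether an ethyl or an amine can replace the methyl of the 5-methyl-1,2-oxazol-3-yl group with the read-out held. Also open, as far as these compounds go, is how a phenyl ring at this position would compare.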